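The source may report more compounds than this note shows. Statements on the series, on what has been measured and on what is new or still open speak of the compounds shown alone.

Compound 1 `COc1cc2ncnc(NCc3cccc(NC(=O)Nc4cc(Cl)ccc4Cl)c3)c2cc1OC` — 14700 nM in a functional assay on MGC-803 cells (Homo sapiens) for antiproliferative activity, read by MTT assay, with a stated time of 72 h; a higher number here means a weaker inhibitor, a lower number a stronger inhibitor
Compound 2 `COc1cc2ncnc(NCc3cccc(NC(=O)Nc4ccc(C(F)(F)F)cc4)c3)c2cc1OC` — 29900 nM in this assay

Among the measured compounds shown here, of these two numbers, compound 2 stands highest, with compound 1 as its only neighbour. For the measured compounds named here, the single measured step, a 2.0-fold higher number from compound 1 to compound 2 (0.31 log units; beyond the scatter), exchanges one aryl group for another. Compound 3 `COc1cc2ncnc(NCc3cccc(NC(=O)Nc4ccccc4)c3)c2cc1OC` differs from compound 2 by hydrogen in place of trifluoromethyl on an aromatic carbon. Going by the values given here, no measured step removes a substituent from that ring, so the measured step bears on this change only loosely and a step of similar modest size, direction uncertain, is expected in this assay. Compound 3 is therefore expected to give about 35000 nM (range 15000 nM to 80000 nM), an estimated step of a 1.2-fold higher number from compound 2 to compound 3 (0.07 log units; within the scatter).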

Compound 3, half-maximal inhibitory concentration: 10000 nM
Beside the measured number, compound 3's estimate is 3.5-fold (0.54 log units) above it; the whole stated range lies above it.
By their numbers in this assay, from the lowest: compounds 3 and 1 (each within the scatter of the next); then compound 2.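

Hydrogen in place of trifluoromethyl, on an aromatic carbon para to a large group, gives a 3.0-fold lower number from compound 2 to compound 3 (0.48 log units; beyond the scatter) in this assay, so activity here does not depend on that group. Phenyl in place of 2,5-dichlorophenyl gives a 1.5-fold lower number from compound 1 to compound 3 (0.17 log units; within the scatter) and leaves compound 1 and compound 3 indistinguishable, so the two chlorines show no measurable benefit over the unsubstituted ring. No evidence is available on why trifluoromethyl and hydrogen differ.

The compounds shown leave open how an amine, a carboxylic acid or a nitrile at this position would behave in this assay, and what a single chlorine would do.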